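The compounds below may be only part of what the source reports. "The series", "measured", "known", "first", "only" and "open" are said of these compounds alone.

Measured so far in a physicochemical assay for solubility, using the shake flask method, in simulated intestinal fluid, measured as kinetic solubility, with a stated time of 2 h, at 25 degrees C, at pH 6.5; on this read-out lower numbers stand for lower solubility and higher numbers for higher solubility:
- Compound 1 `COc1cccc(CN2C(=O)c3c(C)nc(-c4nc(C)no4)c(N)c3C2=O)c1`: < 5000 nM
- Compound 2 `Cc1noc(-c2nc(C)c3c(c2N)C(=O)N(Cc2ccccc2Cl)C3=O)n1`: < 5000 nM
- Compound 3 `Cc1noc(-c2nc(C)c3c(c2N)C(=O)N(Cc2ccc(Cl)cn2)C3=O)n1`: < 5000 nM

Each of these entries is a limit of the assay and not a number. Compound 3 gives < 5000 nM, which is likewise only a limit. All three compounds share this one mark: the limit of < 5000 nM in this assay, at which 3 of the 3 values shown sit.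

Compound 4 `Cc1noc(-c2nc(C)c3c(c2N)C(=O)N(Cc2ccc(C#N)cc2)C3=O)n1` has 4-cyanophenyl in place of 5-chloropyridin-2-yl on a saturated chain carbon bound to an amide-type nitrogen in a ring.

Two measured changes at that same place bear on this one. Among the compounds with values here, the first is a step that the two limits leave unreadable from compound 1 to compound 3, and the second is a step that the two limits leave unreadable from compound 2 to compound 3. Neither gives a usable size, so no step beyond the usual scatter is expected in this assay, and no direction can be predicted. The expected change is a step that the limit leaves unreadable from compound 3 to compound 4. For compound 4 the estimate is 4000 nM, with an expected range of 1500 nM to 7000 nM.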

Compound 4, solubility: < 5000 nM
Compound 4: a limit, no number; the forecaster's own chance of this, stated with the estimate: 85%; the middle value lies beyond the limit too.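

In this assay compound 4 gives < 5000 nM, which is a limit and not a number. No step can be read from compound 1, compound 2 or compound 3 to compound 4. The compounds shown leave open how far their solubilities differ, if at all, and all of them share one mark: the limit of < 5000 nM in this assay, at which 4 of the 4 values shown sit.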